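The source may hold more compounds than are shown below. What is called first, only, known or untested is meant among the compounds shown, and "the series" means these compounds.

The measured set: compound 1 `COc1ccc(OC)c(-c2cc(-c3ccccc3)nn2-c2ccc(S(=O)(=O)NC(C)=O)cc2)c1`, which in a functional assay on cells (Melanoma cell, Homo sapiens) for cytotoxicity, read by sulforhodamine B assay, with a stated time of 48 h (a lower number here means a stronger inhibitor of growth, a higher number a weaker inhibitor of growth), gives 15400 nM; compound 2 `Oc1ccc(O)c(-c2cc(-c3ccccc3)nn2-c2ccccc2)c1`, which gives 22600 nM; compound 3 `NS(=O)(=O)c1ccc(-n2nc(-c3ccccc3)cc2-c2cc(O)ccc2O)cc1`, which gives 61900 nM.

Compound 3 stands highest of the three numbers in this assay: compound 2 is nearest, compound 1 furthest. Going by the values given here, the only single-point step among the measured compounds is a 2.7-fold higher number from compound 2 to compound 3 (0.44 log units; beyond the scatter), so adding the sulfamoyl group to the phenyl ring of compound 2 raised the number by a modest amount.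

Compound 4 `CC(=O)NS(=O)(=O)c1ccc(-n2nc(-c3ccccc3)cc2-c2cc(O)ccc2O)cc1` differs from compound 3 in one place: acetyl in place of hydrogen on a sulfonamide nitrogen. Among the compounds with values here, no measured pair isolates this change. Within the data shown here, compound 1 carries the acetylsulfamoyl group of compound 4, but it also bears two methoxy groups where compound 4 and compound 3 bear two hydroxy groups, so the values of compound 1 and compound 3 show only that the compound with acetylsulfamoyl and methoxy groups gave the lower number; how much of that belongs to the acetyl alone cannot be read from them. A step in this assay of modest size toward a lower number, or none beyond the scatter, is therefore expected for compound 4, a 1.6-fold lower number from compound 3 to compound 4 (0.21 log units; within the scatter). Compound 4 is estimated at 38000 nM, within 14000 nM to 95000 nM.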

Compound 4, concentration for 50% growth inhibition: 84800 nM
Estimate against measurement, compound 4: 2.2-fold (0.35 log units) below; low and high end bracket the measured number.
By their numbers in this assay, from the lowest: compounds 1 and 2 (each within the scatter of the next); then compounds 3 and 4 (each within the scatter of the next).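

In this assay the acetyl in place of hydrogen on the sulfonamide nitrogen gives a 1.4-fold higher number from compound 3 to compound 4 (0.14 log units; within the scatter), so at this nitrogen the change cannot be told from the scatter. Sulfamoyl and acetylsulfamoyl therefore read alike against the unsubstituted phenyl of compound 2: beside the earlier 2.7-fold higher number from compound 2 to compound 3 (0.44 log units; beyond the scatter) now stands a 3.8-fold higher number from compound 2 to compound 4 (0.57 log units; beyond the scatter), and both steps lie beyond the scatter. The lower number of compound 1 no longer points to the acetylsulfamoyl group, since compound 4 carries that group too, and the single change of 2,5-dihydroxyphenyl in place of 2,5-dimethoxyphenyl gives a 5.5-fold higher number from compound 1 to compound 4 (0.74 log units; beyond the scatter), which places the difference with the methoxy groups among these compounds.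

No measurement among those given speaks to what lies behind these numbers. Still open, going by these compounds, is whether a methyl or a longer acyl chain such as propanoyl on the sulfonamide nitrogen, or a carboxylic acid in place of the whole sulfamoyl group, would stay within the scatter of compound 3, and whether the methoxy groups would give the same step with a plain sulfamoyl group on the ring.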